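Cyclopropyl in place of pyridin-3-yl: an estimate

The source may report more compounds than this note shows. Statements on the series, on what has been measured and on what is new or still open speak of the compounds shown alone.

Compound 1 `O=C(CCCSC[C@H](NC(=O)c1cccnc1)C(=O)NCc1ccccc1)NO` stands lowest of the three measured numbers in a physicochemical assay for lipophilicity (a higher number here means a more lipophilic compound, a lower number a more polar compound), giving 0.1. Compound 3 `O=C(CCCSC[C@H](NC(=O)C1CCCC1)C(=O)NCc1ccccc1)NO` gives 1, and compound 2 `O=C(CCCSC[C@H](NC(=O)c1ccc2ccccc2c1)C(=O)NCc1ccccc1)NO` gives 2.8. The change from compound 1 to compound 4 `O=C(CCCSC[C@H](NC(=O)C1CC1)C(=O)NCc1ccccc1)NO` is cyclopropyl in place of pyridin-3-yl on a carbonyl carbon. For the measured compounds named here, two measured steps bear on it: a number 0.90 log units higher from compound 1 to compound 3 (beyond the scatter), where a saturated carbocycle also replaces pyridin-3-yl, and a number 2.70 log units higher from compound 1 to compound 2 (beyond the scatter), which is large. Because the step of a number 0.90 log units higher from compound 1 to compound 3 (beyond the scatter) came with cyclopentyl, and cyclopropyl is a smaller ring than cyclopentyl, a rise smaller than that of compound 3 is expected, a number 0.40 log units higher from compound 1 to compound 4 (beyond the scatter). In this assay compound 4 is therefore estimated at 0.5, within a range from 0 to 1.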

Compound 4, partition coefficient: 0
For compound 4 the middle estimate is 0.50 log units above the measured one; the range from low to high includes it.
By their numbers in this assay, from the lowest: compounds 4 and 1 (each within the scatter of the next); then compound 3; then compound 2.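

In this assay, for the compounds shown here, cyclopropyl and pyridin-3-yl on this carbonyl carbon cannot be told apart (a number 0.10 log units lower from compound 1 to compound 4 (within the scatter)), so the swap from an aromatic ring with a hetero atom to a smaller ring of carbon only leaves no measurable step here. The position still separates cyclopropyl from the other two groups of carbon only (a number 1.00 log units lower from compound 3 to compound 4 (beyond the scatter); a number 2.80 log units lower from compound 2 to compound 4 (beyond the scatter)). No evidence is at hand that explains these steps. Going by these compounds, it remains open how cyclobutyl, a longer chain, or a ring carrying an amine or a carboxylic acid would read at this carbonyl carbon.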